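Pyrrolidin-1-yl for cyclopentylamino on the shared core

This account rests on a few compounds, and the source may have more. Where it says the series, first, only, none or still open, it means among the compounds named here.

In a functional assay on ECa-109 cells for inhibition, with ECa-109 cell line (Homo sapiens) as the target, read by sulforhodamine B assay (on this read-out higher numbers stand for weaker inhibition and lower numbers for stronger inhibition), compound 2 `O=C1C(NC2CCCC2)=CC(=O)c2c1nc1n2[C@H]2OC[C@@H](O)[C@H]2OC1` reads > 16000 nM, which is a limit and not a number. Compound 1 `O=C1C=C(NCc2ccccc2)C(=O)c2c1nc1n2[C@H]2OC[C@@H](O)[C@H]2OC1` reads > 8000 nM, also a limit. Compound 3 `O=C1C=C(Nc2ccccc2F)C(=O)c2c1nc1n2[C@H]2OC[C@@H](O)[C@H]2OC1` gives 2760 nM. Going by the values given here, the only measured step is an at least 2.8-fold lower number from compound 1 to compound 3 (0.46 log units; beyond the scatter), with 2-fluorophenyl in place of benzyl on an amine nitrogen. Compound 4 `O=C1C(N2CCCC2)=CC(=O)c2c1nc1n2[C@H]2OC[C@@H](O)[C@H]2OC1` instead carries pyrrolidin-1-yl in place of cyclopentylamino on a double-bonded ring carbon. No aromatic ring enters here, so the gain in this assay seen in an at least 2.8-fold lower number from compound 1 to compound 3 (0.46 log units; beyond the scatter) carries over only loosely, and no step beyond the scatter is expected. The expected change is an at least 1.1-fold lower number from compound 2 to compound 4 (0.05 log units; that floor lies within the scatter). For compound 4 the estimated value is 14000 nM, with an expected range of 5000 nM to 40000 nM.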

Compound 4, half-maximal inhibitory concentration: > 16000 nM
Compound 4: a limit, no number; the forecaster's own chance of this, stated with the estimate: 55%; at least 1.1-fold (0.05 log units) between middle value and limit.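

No step from compound 2 to compound 4 can be read, because both readings are limits and not numbers: the limit of > 16000 nM in this assay, at which 2 of the 4 values shown sit.

On these data alone, whether pyrrolidin-1-yl or cyclopentylamino gives the lower number on the shared core stays open.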